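The source may report more compounds than this note shows. Statements on the series, on what has been measured and on what is new or still open speak of the compounds shown alone.

Measured compounds:
compound 1 `COC(=O)/C=C/c1cccc(N(Cc2ccc(-c3cccc(Cl)c3)cc2)C(=O)C2CCCCC2)c1` gives 94 nM in an assay on isolated protein with Bile acid receptor (Homo sapiens) as the target; on this read-out lower numbers stand for an effect already at smaller amounts and higher numbers for an effect only at larger amounts of compound;
compound 2 `COC(=O)/C=C/c1cccc(N(Cc2ccccc2)C(=O)C2CCCCC2)c1` gives > 1000 nM in this assay, which is a limit of the assay and not a number;
compound 3 `COC(=O)/C=C/c1cccc(N(Cc2cc(OC)cc(OC)c2)C(=O)C2CCCCC2)c1` gives 606 nM in this assay.

Among the numbers shown in this assay, compound 3 carries the highest one, with compound 1 the nearest and lower. Compound 4 `COC(=O)/C=C/c1cccc(N(Cc2ccc(/C=C/C(=O)O)cc2)C(=O)C2CCCCC2)c1` differs from compound 3 in one place: 4-(2-carboxyethenyl)phenyl in place of 3,5-dimethoxyphenyl on a saturated chain carbon bound to an amide-type nitrogen. For the measured compounds named here, two measured steps bear on this change. Removing the 3-chlorophenyl from the benzyl ring gave an at least 10-fold higher number from compound 1 to compound 2 (1.02 log units; beyond the scatter), while placing the two methoxy groups on that ring gave an at least 1.6-fold lower number from compound 2 to compound 3 (0.21 log units; that floor lies within the scatter). A substituent on the same ring thus once moved the number far down and once only a little; a new group there is expected to lower the number again for compound 4, by a 2.8-fold lower number from compound 3 to compound 4 (0.44 log units; beyond the scatter). Compound 4 is therefore estimated at 220 nM, with a range from 60 nM to 800 nM.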

Compound 4, half-maximal effective concentration: > 1000 nM
Compound 4: only a limit was reported; the forecaster's own chance of this, stated with the estimate: 10%; at least 4.5-fold (0.65 log units) between middle value and limit.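

Putting 2-carboxyethenyl in place of 3-chlorophenyl on an aromatic carbon gave an at least 10-fold higher number from compound 1 to compound 4 (1.02 log units; beyond the scatter), so the low number of compound 1 does not carry over to every group placed there. For the compounds shown here, the exchange of 3,5-dimethoxyphenyl for 4-(2-carboxyethenyl)phenyl gave an at least 1.6-fold higher number from compound 3 to compound 4 (0.21 log units; that floor lies within the scatter), and since that floor lies within the scatter, this step shows only that the new group brought no lowering of the number. The value of compound 4 is a limit of the assay, and its step to compound 2 cannot be read, as compound 2 carries a limit too: the limit of > 1000 nM in this assay, at which 2 of the 4 values shown sit.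

As far as these compounds go, how far the true value of compound 4 lies past its limit remains open. So does whether a methyl ester in place of the carboxylic acid, or a phenyl group on the ethenyl chain, would read differently at this place.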